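Dropping One Methyl From a Weakly Active Thiol

A few compounds are considered here, and "the series" means these few. Any claim that something is new, unique, unknown or untested is made for them only; others in the source may bear on it.

Measured compounds:
compound 1, `CCCc1ncc2cnnc(S)n12`, > 48000 nM in a functional assay for inhibition, with Homo sapiens as the target; a lower number here means a stronger inhibitor, a higher number a weaker inhibitor
compound 2, `CCCc1nc(C)c2c(C)nnc(S)n12`, 45000 nM in this assay

For compound 1 the result is a limit of the assay, not a number. Within the data shown here, compound 2 gives the only actual number among the two values shown, and it sits close to that limit (the limit of > 48000 nM in this assay, at which 1 of the 2 values shown sits); both compounds are therefore weak inhibitors in this assay.

Compound 3, `CCCc1nc(C)c2cnnc(S)n12`, has not been measured. It differs from compound 2 in one place: hydrogen in place of methyl on an aromatic carbon, on an aromatic carbon of a six-membered aromatic ring with 3 nitrogen, next to the ring nitrogen. Among the measured compounds shown here, no step between measured compounds is available. Compound 1, which carries no methyl at all, reaches only the limit, and compound 2 is already weak, so no gain beyond the scatter is expected, and a small loss is the likelier direction. Compound 3 is therefore expected to give about 55000 nM in this assay, somewhere between 30000 nM and 120000 nM, a step of a 1.2-fold higher number from compound 2 to compound 3 (0.09 log units; within the scatter).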

Compound 3, half-maximal inhibitory concentration: 10000 nM
Compound 3: middle estimate off by 5.5-fold (0.74 log units), on the high side; the whole stated range lies above it.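

In this assay, the methyl on the six-membered aromatic ring is not a neutral group: taking it away gives a 4.5-fold lower number from compound 2 to compound 3 (0.65 log units; beyond the scatter). A methyl on an aromatic carbon can therefore lower or raise the number depending on where it sits, since adding the other methyl gives an at least 4.8-fold lower number from compound 1 to compound 3 (0.68 log units; beyond the scatter). That second step is only a lower bound, because compound 1 gives a limit of the assay rather than a number: the limit of > 48000 nM in this assay, at which 1 of the 3 values shown sits.

As far as these compounds go, what remains open is whether the loss seen with methyl at this position would also appear with another group there, such as a fluorine atom or a hydroxyl. From the compounds shown here alone, it is also open how far compound 3, still a weak inhibitor at 10000 nM, would move if an amine replaced the sulfanyl group or a longer chain replaced the propyl group.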